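The source may hold more compounds than are shown below. What is called first, only, known or untested is meant among the compounds shown, and "the series" means these compounds.

Measured so far:
compound 1 `COc1cccc(NC2=CC(=O)c3c(nc4n3[C@H]3OC[C@@H](O)[C@H]3OC4)C2=O)c1`, 3340 nM
compound 2 `O=C1C=C(NCc2ccccc2)C(=O)c2c1nc1n2[C@H]2OC[C@@H](O)[C@H]2OC1`, > 8000 nM

In a functional assay on ECa-109 cells for inhibition, with ECa-109 cell line (Homo sapiens) as the target, read by sulforhodamine B assay (on this read-out higher numbers stand for weaker inhibition and lower numbers for stronger inhibition), compound 1 gives 3340 nM. For compound 2 the read-out in this assay is only a limit, > 8000 nM. Compound 2 sits at the limit of > 8000 nM in this assay, at which 1 of the 2 values shown sits. Compound 3 `O=C1C=C(Nc2ccccc2F)C(=O)c2c1nc1n2[C@H]2OC[C@@H](O)[C@H]2OC1` is still to be measured. It differs from compound 2 by 2-fluorophenyl in place of benzyl on an amine nitrogen. Where compound 2 carries benzylamino, an arylamino group is carried by compound 1, which reached 3340 nM in this assay. On that basis a step toward stronger inhibition is expected, an at least 2.0-fold lower number from compound 2 to compound 3 (0.30 log units; that floor lies within the scatter). Compound 3 is estimated at 4000 nM, within a range of 1500 nM to 10000 nM.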

Compound 3, half-maximal inhibitory concentration: 2760 nM
Estimate against measurement, compound 3: 1.4-fold (0.16 log units) above; low and high end bracket the measured number.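

In this assay the change from benzyl to 2-fluorophenyl on the amine nitrogen gives an at least 2.8-fold lower number from compound 2 to compound 3 (0.46 log units; beyond the scatter) as a floor on the true step. Compound 2 is a limit and not a number: the limit of > 8000 nM in this assay, at which 1 of the 3 values shown sits. Compound 1 and compound 3, both arylamino, now each have a measured number, while the benzylamino compound has only a limit.

Whether the fluorine contributes at all remains open, as no unsubstituted phenylamino compound is shown. Also open, as far as these compounds go, is how a simple alkylamine or a longer chain carrying the phenyl ring would read on this nitrogen.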